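The source may report more compounds than this note shows. Statements on the series, on what has been measured and on what is new or still open speak of the compounds shown alone.

Compound 1 `COc1cccc2c(=O)c(Cc3ccccc3)c(C)[nH]c12` is a fused two-ring core carrying a methoxy group on an aromatic carbon and a benzyl side chain. In a physicochemical assay for solubility, read by HPLC, at pH 7.4 (a higher number here means a more soluble compound, a lower number a less soluble compound), compound 1 gives > 20000 nM, which is a limit of the assay rather than a number; it stands at the limit of > 20000 nM in this assay, at which 1 of the 3 values shown sits. Compound 2 `Cc1[nH]c2c(Cl)cccc2c(=O)c1Cc1ccccc1` differs from compound 1 by one change, (chloro in place of methoxy on an aromatic carbon). In this assay compound 2 gives 5000 nM, and the step of an at least 4.0-fold lower number from compound 1 to compound 2 (0.60 log units; beyond the scatter) lies beyond the usual scatter.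

Compound 3 `COc1ccc2c(=O)c(Cc3ccccc3)c(C)[nH]c2c1` has the same atoms as compound 1 joined differently; the difference between the two cores is not broken down here. In this assay compound 3 gives 5000 nM, the same figure as compound 2 and within the scatter of it.

Compound 4 `Cc1[nH]c2cc(Cl)ccc2c(=O)c1Cc1ccccc1` is not yet measured. It differs from compound 3 by chloro in place of methoxy on an aromatic carbon. Among the measured compounds shown here, this is the same kind of change as the one from compound 1 to compound 2, not the same change: there the carbon was ortho to a fused ring and meta to a fused ring, here it is meta to a fused ring and para to a fused ring. Because the measured step of an at least 4.0-fold lower number from compound 1 to compound 2 (0.60 log units; beyond the scatter) lowered solubility, a step of a 3.3-fold lower number from compound 3 to compound 4 (0.52 log units; beyond the scatter) is expected here as well. Compound 4 is expected to give about 1500 nM in this assay. The estimate for compound 4 is expected to fall between 500 nM and 5000 nM.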

Compound 4, solubility: < 2000 nM
Compound 4 was reported as a limit (the forecaster's own chance of this, stated with the estimate: 10%); the middle value does not contradict the limit.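

Compound 4 is reported as a limit of the assay and not as a number: the limit of < 2000 nM in this assay, at which 1 of the 4 values shown sits. In this assay, replacing methoxy with chloro gives an at least 4.0-fold lower number from compound 1 to compound 2 (0.60 log units; beyond the scatter), and on the other core it gives an at least 2.5-fold lower number from compound 3 to compound 4 (0.39 log units; beyond the scatter), so the direction of the change carries over between these two pairs, even though the group sits at a different place on the ring in each. Each step rests on a limit and therefore gives only a smallest possible size, so the data do not show whether the change has the same size on both cores, and two pairs do not establish a rule for the whole series.

The compounds shown carry only methoxy or chloro at these places on the ring, so it remains open how an amine, a carboxylic acid or a longer chain such as butoxy would read in this assay. Going by these compounds, it also remains open how the number would respond to a change in the benzyl side chain or at the ring nitrogen, since all four compounds share both features.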